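Propyl in place of methoxy on a carbonyl carbon

The source may hold more compounds than are shown below. What is called first, only, known or untested is meant among the compounds shown, and "the series" means these compounds.

Three compounds share one core and differ only in the group on a carbonyl carbon: compound 1 (`CC(=O)c1ccc(NCc2cncn2Cc2ccc(-c3ccccc3)cc2)cc1-c1ccccc1`), compound 2 (`CNC(=O)c1ccc(NCc2cncn2Cc2ccc(-c3ccccc3)cc2)cc1-c1ccccc1`) and compound 3 (`COC(=O)c1ccc(NCc2cncn2Cc2ccc(-c3ccccc3)cc2)cc1-c1ccccc1`). In a toxicity assay on NIH3T3 cells (Mus musculus) for cytotoxicity, read by resazurin assay (on this read-out higher numbers stand for an effect only at larger amounts of compound and lower numbers for an effect already at smaller amounts), compound 3 gives > 1000 nM as a limit and not a number. Compound 2 gives > 1000 nM as a limit too. Compound 1, with methyl on that carbonyl carbon, gives > 10000 nM as a limit as well. Compound 3 therefore stands on the limit of > 1000 nM in this assay, at which 2 of the 3 values shown sit, with no number to place it more closely.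

The next compound, compound 4 (`CCCC(=O)c1ccc(NCc2cncn2Cc2ccc(-c3ccccc3)cc2)cc1-c1ccccc1`), carries propyl in place of methoxy on a carbonyl carbon. The measured steps at that place are a step that the two limits leave unreadable from compound 1 to compound 3 and a step that the two limits leave unreadable from compound 1 to compound 2 and a step that the two limits leave unreadable from compound 2 to compound 3 and none of them has a readable size. They therefore give no firm direction. Compound 1 is the closest guide, since it too has a carbon group in that place, and its limit of > 10000 nM suggests no effect at low amounts. The expected outcome in this assay is a step that the limit leaves unreadable from compound 3 to compound 4 and it points, if anywhere, towards higher numbers. Compound 4 is estimated at 10000 nM within an expected range from 3000 nM to 30000 nM and will most likely be reported only as a limit.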

Compound 4, half-maximal effective concentration: > 10000 nM
Compound 4 ended at the assay's limit; the forecaster's own chance of this, stated with the estimate: 85%; the middle value lies on the limit itself.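

In this assay compound 4 gives > 10000 nM as a limit and not a number. Among these compounds, compound 1, compound 2 and compound 3 also stand only as limits, and no step from any of them to compound 4 can be read. The compounds shown leave open at what concentration any of the four has an effect in this assay and whether the group on the carbonyl carbon changes it.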